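Swapping a Para Fluoro for a Cyano Group

This account rests on a few compounds, and the source may have more. Where it says the series, first, only, none or still open, it means among the compounds named here.

Three compounds share one core, a cyclohexene carrying a conjugated dienone that ends in a benzene ring. Compound 1 `CC1=C(/C=C/C(=O)/C=C/c2ccccc2)C(C)(C)CCC1` carries no substituent on that ring, compound 2 `CC1=C(/C=C/C(=O)/C=C/c2ccc(Cl)cc2)C(C)(C)CCC1` a chloro group, and compound 3 `CC1=C(/C=C/C(=O)/C=C/c2ccc(F)cc2)C(C)(C)CCC1` a fluoro group. In a functional assay on Hep cells (Homo sapiens) for cytotoxicity, read by sulforhodamine B assay, with a stated time of 48 h (a higher number here means a weaker inhibitor, a lower number a stronger inhibitor), compound 1 gives 62200 nM, compound 2 gives 90600 nM, and compound 3 gives 55800 nM. Compound 3 has the lowest of the three numbers, but its neighbours sit close: a 1.1-fold lower number from compound 1 to compound 3 (0.05 log units; within the scatter) and a 1.6-fold lower number from compound 2 to compound 3 (0.21 log units; within the scatter), and likewise a 1.5-fold higher number from compound 1 to compound 2 (0.16 log units; within the scatter), so none of these differences can be told from repeat scatter.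

Compound 4 `CC1=C(/C=C/C(=O)/C=C/c2ccc(C#N)cc2)C(C)(C)CCC1` differs from compound 3 by cyano in place of fluoro on an aromatic carbon. Within the data shown here, no measured step involves a cyano group, so the bearing steps are only those above, in which a hydrogen, a chloro and a fluoro at this position all gave numbers within the scatter of one another. On that basis the step of a 1.1-fold higher number from compound 3 to compound 4 (0.05 log units; within the scatter) is expected to stay within the scatter as well, in no particular direction. The estimate for compound 4 in this assay is therefore 62000 nM, with a range from 25000 nM to 160000 nM.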

Compound 4, half-maximal inhibitory concentration: 45600 nM
For compound 4 the middle estimate is 1.4-fold (0.13 log units) above the measured one, and the stated range covers the measured number.
By their numbers in this assay, from the lowest: compounds 4, 3, 1 and 2 (each within the scatter of the next).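

In this assay, cyano in place of fluoro gives a 1.2-fold lower number from compound 3 to compound 4 (0.09 log units; within the scatter), and the comparisons with the other two compounds read the same way: a 1.4-fold lower number from compound 1 to compound 4 (0.13 log units; within the scatter) and a 2.0-fold lower number from compound 2 to compound 4 (0.30 log units; within the scatter). Until now, this position on the aromatic ring had carried only hydrogen, chloro and fluoro, whereas cyano brings 2 heavy atoms, a triple bond and a hydrogen-bond acceptor. Even this different kind of group produces no step beyond the scatter, so all four compounds remain indistinguishable in this cell assay, and the position has yet to show any clear link between the group placed there and the number obtained.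

Whether a group such as an amine, a carboxylic acid or a longer chain at this same position would move the number beyond the scatter remains an open question. The data shown offer no measured explanation for how closely these four numbers sit together.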